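A few compounds are considered here, and "the series" means these few. Any claim that something is new, unique, unknown or untested is made for them only; others in the source may bear on it.

Measured compounds:
compound 1, `O=C(Nc1cccc(-n2cc(-c3ccncc3)c(-c3cc(O)cc(Cl)c3)n2)c1)Nc1ccc(Cl)c(Cl)c1`, 100%
compound 2, `COc1cc(Cl)cc(-c2nn(-c3cccc(NC(=O)Nc4ccc(Cl)c(C(F)(F)F)c4)c3)cc2-c2ccncc2)c1`, 98%

Both compounds were examined in a functional assay on SN12C cells (Homo sapiens) for inhibition, read by sulforhodamine B assay, with a stated time of 48 h, tested at 0.01 uM; on this read-out higher numbers stand for a weaker effect at the one concentration tested and lower numbers for a stronger effect. In this assay compound 1 gives 100% and compound 2 gives 98%. These two numbers lie within the usual scatter of each other, so neither compound can be said to act differently from the other at the single concentration tested; both sit at the end of the scale where essentially no effect is seen. Compound 2 stands, in short, at the same level as compound 1.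

Compound 3, `COc1cc(Cl)cc(-c2nn(-c3cccc(NC(=O)Nc4ccc(Cl)c(Cl)c4)c3)cc2-c2ccncc2)c1`, has not yet been measured. It differs from compound 2 in one place: chloro in place of trifluoromethyl on an aromatic carbon. Among the measured compounds shown here, since the only two measured numbers show no effect, the change from compound 2 to compound 3 is expected to bring no step beyond the scatter, and the estimated step is no change at the digits printed from compound 2 to compound 3 (within the scatter). Compound 3 is therefore expected to give 98%, with a range from 88% to 104%.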

Compound 3, a percentage reported as activity, at one concentration (the size of the read-out at that concentration, not a potency): 97%
Beside the measured number, compound 3's estimate is 1 percentage points above it, within the range that was stated.
By their numbers in this assay, from the lowest: compounds 3, 2 and 1 (each within the scatter of the next).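

In this assay, chloro in place of trifluoromethyl on this aromatic carbon, ortho to a chloro group, gives a number 1 percentage points lower from compound 2 to compound 3 (within the scatter), so at this position the two groups cannot be told apart by this read-out. The second comparison concerns a different place, the oxygen on the other aromatic ring: methyl in place of hydrogen there gives a number 3 percentage points lower from compound 1 to compound 3 (within the scatter), so this change also cannot be told apart here. Nothing available explains either result.

From the compounds shown here alone, all three compounds sit near the no-effect end of the scale at a single concentration, so it remains open whether either change would matter under conditions where an effect appears. Also open, going by these compounds, is whether an amine at the aromatic position, or a longer chain on the oxygen, would move the number beyond the scatter.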